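Para substituent on the hydrazone aryl: chloro to dimethylamino

The source may hold more compounds than are shown below. What is called first, only, known or untested is meant among the compounds shown, and "the series" means these compounds.

Measured compounds in an ADME assay on cells (Splenocyte, Mus musculus, strain BALB/c) for cytotoxicity, read by thymidine incorporation, with a stated time of 24 h; on this read-out lower numbers stand for stronger inhibition and higher numbers for weaker inhibition:
compound 1 `O=C(CCN1CCN(c2ccnc3cc(Cl)ccc23)CC1)N/N=C/c1c[nH]c2ccccc12` gives 5700 nM
compound 2 `O=C(CCN1CCN(c2ccnc3cc(Cl)ccc23)CC1)N/N=C/c1ccccc1Cl` gives 10800 nM
compound 3 `O=C(CCN1CCN(c2ccnc3cc(Cl)ccc23)CC1)N/N=C/c1ccc(Cl)cc1` gives 200 nM

Compound 3 stands lowest of the three in this assay, and both of its steps to the others lie beyond the scatter. The two steps that reach it both change the aryl group on the carbon with a double bond to nitrogen: a 29-fold lower number from compound 1 to compound 3 (1.45 log units; beyond the scatter) and a 54-fold lower number from compound 2 to compound 3 (1.73 log units; beyond the scatter). The remaining pair, compound 1 against compound 2, differs only within the scatter: a 1.9-fold higher number from compound 1 to compound 2 (0.28 log units; within the scatter).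

Compound 4 `CN(C)c1ccc(/C=N/NC(=O)CCN2CCN(c3ccnc4cc(Cl)ccc34)CC2)cc1` keeps the shared core and the same aryl ring, but with the change (dimethylamino in place of chloro on an aromatic carbon). Within the data shown here, no measured step varies a substituent on this ring while keeping the ring itself; the two relevant steps show only that the 4-chlorophenyl is the one arrangement among those tested that gives a low number, and that moving away from it in either direction tried so far gave large rises. On that basis a large rise is expected for compound 4 as well, by about a 15-fold higher number from compound 3 to compound 4 (1.18 log units; beyond the scatter). The estimate for compound 4 in this assay is 3000 nM, with a range of 700 nM to 12000 nM.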

Compound 4, half-maximal inhibitory concentration: > 100000 nM
Compound 4: no number, only a limit; the forecaster's own chance of this, stated with the estimate: 5%; at least 33-fold (1.52 log units) between middle value and limit.
By their numbers in this assay, from the lowest: compound 3; then compounds 1 and 2 (each within the scatter of the next). At a limit, above all of these: compound 4.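

In this assay compound 4 gives > 100000 nM, which is a limit of the assay and not a number: the limit of > 100000 nM in this assay, at which 1 of the 4 values shown sits. This position, on an aromatic carbon para to a large group, now has its first change of substituent with the ring itself kept, and the step is large: an at least 500-fold higher number from compound 3 to compound 4 (2.69 log units; beyond the scatter). The low number of compound 3 therefore does not follow from a substituent at this place as such, as compound 4 carries dimethylamino there and still stands clear of both other aryl variants: an at least 9.2-fold higher number from compound 2 to compound 4 (0.96 log units; beyond the scatter) and an at least 17-fold higher number from compound 1 to compound 4 (1.24 log units; beyond the scatter).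

With only chloro and dimethylamino at this place, and one of the two reported only as a limit, the compounds shown give neither the full size of the change nor a trend across substituents. From the compounds shown here alone, whether a fluoro, a bromo, a methyl, a methoxy or a primary amine on the same aromatic carbon would stay close to compound 3 or rise towards compound 4 remains open.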